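Fluoro for hydrogen in a series sitting at the assay limit

This account rests on a few compounds, and the source may have more. Where it says the series, first, only, none or still open, it means among the compounds named here.

The series is followed in a functional assay on NCI-H460 cells (Homo sapiens) for cytotoxicity, read by MTT assay, with a stated time of 48 h; a lower number here means a stronger inhibitor, a higher number a weaker inhibitor. Compound 1 `COc1ccc2[nH]c(=O)c(-c3nc4ccccc4[nH]3)cc2c1` gives only a limit here, > 100000 nM, and not a number. Compound 2 `Cc1cc2nc(-c3cc4ccccc4[nH]c3=O)[nH]c2cc1C` likewise returns only a limit, > 100000 nM. Compound 3 `Cc1ccc2[nH]c(=O)c(-c3nc4cc([N+](=O)[O-])ccc4[nH]3)cc2c1` also returns only a limit, > 100000 nM. Going by the values given here, compound 1 therefore stands where every value so far stands, at the limit of > 100000 nM in this assay, at which 3 of the 3 values shown sit; no compound in the set has yet returned a number, so no measured step exists and no gap between steps can be weighed.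

Compound 4 `COc1ccc2[nH]c(=O)c(-c3nc4cc(F)ccc4[nH]3)cc2c1` differs from compound 1 by fluoro in place of hydrogen on an aromatic carbon. Among the compounds with values here, with the whole set at the limit and no measured step to lean on, the expected step in this assay from compound 1 to compound 4 is none beyond the scatter, and the most likely outcome is once more a limit rather than a number. The estimate for compound 4 is 100000 nM, between 30000 nM and 300000 nM. The step this estimate implies is a number no higher from compound 1 to compound 4 (the limit leaves the size open), expected to be none beyond the scatter.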

Compound 4, half-maximal inhibitory concentration: > 100000 nM
Compound 4: only a limit was reported; the forecaster's own chance of this, stated with the estimate: 80%; the middle value sits exactly at the limit.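

Compound 4 gives only a limit in this assay, > 100000 nM, so the step from compound 1 for fluoro in place of hydrogen cannot be read: the limit of > 100000 nM in this assay, at which 4 of the 4 values shown sit.

What the compounds shown leave open is the size of that step, and whether any change on the shared core yields a number in this assay.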